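The source may hold more compounds than are shown below. What is called first, only, known or untested is meant among the compounds shown, and "the series" means these compounds.

Compound 1 `OCc1nnc(-c2ccc(N3CCC(Oc4ccccc4C(F)(F)F)CC3)nn2)s1`: 3.2 nM
Compound 2 `Cc1cccc(OC2CCN(c3ccc(-n4ccnc4)nn3)CC2)c1`: 251 nM
Compound 3 `Cc1ccc(OC2CCN(c3ccc(-n4ccnc4)nn3)CC2)cc1`: 527 nM

In an assay on microsomes from liver for inhibition of acyl-CoA desaturase 1 (Rattus norvegicus) (on this read-out lower numbers stand for stronger inhibition and higher numbers for weaker inhibition), compound 1 stands lowest of the three numbers, well clear of both compound 2 and compound 3, whose numbers lie far higher. Compound 4 `CC(C)Cc1nnc(-c2ccc(N3CCC(Oc4ccccc4C(F)(F)F)CC3)nn2)s1` differs from compound 1 in one place: isopropyl in place of hydroxy on a saturated chain carbon bound to an aromatic carbon. Among the measured compounds shown here, the only measured single-place step, a 2.1-fold higher number from compound 2 to compound 3 (0.32 log units; beyond the scatter), moves a methyl on a phenyl ring and does not touch the hydroxymethyl, so no measured step bears directly on this change. The expectation for compound 4 therefore rests on compound 1 alone, and only a modest step, of uncertain direction, is expected, a 1.9-fold higher number from compound 1 to compound 4 (0.27 log units; within the scatter). Compound 4 is estimated at 6 nM, within a range from 1.5 nM to 25 nM.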

Compound 4, half-maximal inhibitory concentration: 37 nM
Compound 4: the middle estimate sits 6.2-fold (0.79 log units) below what was measured; the measured number lies above the stated range.
By their numbers in this assay, from the lowest: compound 1; then compound 4; then compound 2; then compound 3.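

Among the compounds shown here, this position is not a neutral spot: going from hydroxymethyl to isobutyl gives a 12-fold higher number from compound 1 to compound 4 (1.06 log units; beyond the scatter) in this assay and shows that the group here matters, which the earlier compounds could not show. The change removes the hydrogen-bond donor and acceptor and adds carbon atoms at once, so this single step cannot separate those differences. Nothing available explains the step. Still open, from the compounds shown here alone, is how an amine, a carboxylic acid or a methyl at this position would compare with hydroxymethyl. Going by these compounds, whether a longer chain ending in hydroxy would keep the number of compound 1 is also open.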